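A few compounds are considered here, and "the series" means these few. Any claim that something is new, unique, unknown or untested is made for them only; others in the source may bear on it.

Compound 1 `C[C@H]1N=C2C[C@H]3C[C@H](C3(C)C)[C@@]2(C)OC1=O` and compound 2 `CC1(C)[C@H]2CC3=N[C@H](CCC(=O)O)C(=O)O[C@]3(C)[C@@H]1C2` share one core and were both tested in a functional assay on PC-3 cells (Homo sapiens) for antiproliferative activity, read by sulforhodamine B assay, with a stated time of 48 h (a lower number here means a stronger inhibitor, a higher number a weaker inhibitor), where compound 1 gives 42000 nM and compound 2 gives 38000 nM. Among the measured compounds shown here, the only step measured so far, a 1.1-fold lower number from compound 1 to compound 2 (0.04 log units; within the scatter), lies within the scatter, so compound 2 stands level with compound 1 and neither can be called the stronger of the two. Compound 3 `CC(C)(C)OC(=O)CC[C@H]1N=C2C[C@H]3C[C@H](C3(C)C)[C@@]2(C)OC1=O` has not yet been measured. It differs from compound 2 in one place: tert-butyl in place of hydrogen on an oxygen next to a carbonyl group. For the measured compounds named here, no measured step involves a change of this kind, an ester group put in place of an acid; the one step on record, from compound 1 to compound 2, concerned a different part of the molecule and stayed within the scatter. There is therefore nothing in these numbers that points to a change in either direction, and a step within the scatter, a 1.1-fold lower number from compound 2 to compound 3 (0.04 log units; within the scatter), is what is expected. Compound 3 is accordingly expected to give 35000 nM in this assay, with a range from 12000 nM to 100000 nM.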

Compound 3, half-maximal inhibitory concentration: 55000 nM
For compound 3 the middle estimate is 1.6-fold (0.20 log units) below the measured one; the range from low to high includes it.
By their numbers in this assay, from the lowest: compounds 2, 1 and 3 (each within the scatter of the next).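

Replacing the hydrogen on the oxygen of the carboxy group with tert-butyl, so that carboxy becomes tert-butoxycarbonyl, gives in this assay a step, a 1.4-fold higher number from compound 2 to compound 3 (0.16 log units; within the scatter), that leaves the two compounds level, so at this end of the side chain the free acid and its tert-butyl ester cannot be told apart. Compared with plain hydrogen on the saturated chain carbon bound to a saturated ring carbon, the full (tert-butoxycarbonyl)methyl group gives a 1.3-fold higher number from compound 1 to compound 3 (0.12 log units; within the scatter), so this place on the shared core carries hydrogen, carboxymethyl or (tert-butoxycarbonyl)methyl with all three compounds level, even though the last is much the largest of the three. No measurement at hand offers an explanation for this flat reading.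

These three compounds therefore show no group at this place that separates from the others, and all of them stand at weak numbers in this assay. As far as these compounds go, whether an amine, an amide or a longer chain ending in a phenyl ring would read any differently at this place, or whether a change elsewhere on the core would matter more, remains open.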